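The source may hold more compounds than are shown below. What is called first, only, known or untested is meant among the compounds shown, and "the series" means these compounds.

Compound 1 `O=C(/C=C/c1ccccc1)NS(=O)(=O)c1ccc(F)cc1`: 2.1 ug/mL
Compound 2 `O=C(/C=C/c1ccccc1)NS(=O)(=O)c1ccc(Cl)cc1`: 2.2 ug/mL

Compound 2 holds the higher of these two numbers, though the difference, a 1.0-fold higher number from compound 1 to compound 2 (0.02 log units; within the scatter), lies within the scatter, so the two compounds cannot be told apart. Compound 3 `O=C(/C=C/c1ccccc1)NS(=O)(=O)c1ccc(Br)cc1` differs from compound 2 by bromo in place of chloro on an aromatic carbon. For the measured compounds named here, the one measured step that bears on this, a 1.0-fold higher number from compound 1 to compound 2 (0.02 log units; within the scatter), is a halogen exchange at the same place, and it produced no change beyond the scatter in a functional assay on B16-F10 cells (Mus musculus) for antiproliferative activity, read by ELISA and MTT assay, with a stated time of 48 h; on this read-out higher numbers stand for weaker inhibition and lower numbers for stronger inhibition. A further halogen exchange there is therefore expected to give no step beyond the scatter. Compound 3 is estimated at 2.3 ug/mL, with a range from 1.2 ug/mL to 4.5 ug/mL. The expected step is a 1.0-fold higher number from compound 2 to compound 3 (0.02 log units; within the scatter).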

Compound 3, half-maximal inhibitory concentration: 3.9 ug/mL
The estimate for compound 3 lay 1.7-fold (0.23 log units) below the measured number; measured number inside the range.
By their numbers in this assay, from the lowest: compounds 1, 2 and 3 (each within the scatter of the next).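

In this assay, chloro to bromo on the aromatic carbon gives a 1.8-fold higher number from compound 2 to compound 3 (0.25 log units; within the scatter) and fluoro to bromo gives a 1.9-fold higher number from compound 1 to compound 3 (0.27 log units; within the scatter). Bromo therefore extends the earlier finding: none of the three halogen exchanges at this position gives a step beyond the scatter, so the three compounds cannot be ranked. No measurement offered here explains these numbers. Still open, on these data alone, is whether a group other than a halogen at this position, such as an amine or a carboxylic acid, would give a step beyond the scatter.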